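From 4-methoxybenzyl to 2-methoxybenzyl: an expected step

The source may report more compounds than this note shows. Statements on the series, on what has been measured and on what is new or still open speak of the compounds shown alone.

In a functional assay on HepG2 cells (Homo sapiens) for antiproliferative activity, read by MTT assay, with a stated time of 48 h (on this read-out lower numbers stand for stronger inhibition and higher numbers for weaker inhibition), compound 1 `CCN1C(=O)C(=O)c2cc(-c3ccc(OC)cc3)ccc21` gives 4470 nM, while compound 2 `COc1ccc(CN2C(=O)C(=O)c3cc(-c4ccc(OC)cc4)ccc32)cc1` gives 50 nM. Among the compounds with values here, compound 2 therefore holds the lower of the two numbers measured so far, which means the stronger inhibition. Compound 3 `COc1ccc(-c2ccc3c(c2)C(=O)C(=O)N3Cc2ccccc2OC)cc1` has not yet been measured. It contains the same atoms as compound 2, joined differently: 2-methoxyphenyl in place of 4-methoxyphenyl on a saturated chain carbon bound to an amide-type nitrogen in a ring. Put simply, 4-methoxybenzyl becomes 2-methoxybenzyl.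

Within the data shown here, only one measured step bears on this change: an 89-fold lower number from compound 1 to compound 2 (1.95 log units; beyond the scatter). That large step came with 4-methoxyphenyl in place of methyl at the same place in the molecule. Among the measured compounds shown here, no measured pair compares 4-methoxyphenyl with 2-methoxyphenyl, so the evidence is thin. Compound 3 keeps a methoxyphenyl group there, so its number is expected to stay nearer to that of compound 2 than to that of compound 1. A moderate loss of strength is the cautious expectation in this assay, an estimated 3.0-fold higher number from compound 2 to compound 3 (0.48 log units; beyond the scatter). For compound 3 the estimated value is 150 nM, with a range of 30 nM to 800 nM.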

Compound 3, half-maximal inhibitory concentration: 130 nM
Beside the measured number, compound 3's estimate is 1.2-fold (0.06 log units) above it; low and high end bracket the measured number.
By their numbers in this assay, from the lowest: compound 2; then compound 3; then compound 1.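

In this assay, changing 4-methoxybenzyl to 2-methoxybenzyl brings a 2.6-fold higher number from compound 2 to compound 3 (0.41 log units; beyond the scatter) with the atom count untouched, so at this place the outcome depends on where the methoxy group sits as well as on which atoms are present. That dependence is modest next to what separates these groups from the small group in compound 1: putting 2-methoxyphenyl in place of methyl still gives a 34-fold lower number from compound 1 to compound 3 (1.54 log units; beyond the scatter), so most of the large gain seen with 4-methoxyphenyl survives the change, and among these three compounds both methoxyphenyl groups give far lower numbers than methyl. No measurement at hand says what lies behind either step.

The compounds shown leave open whether the methoxy group is needed at all, as a plain benzyl group could land near compound 2 or near compound 1. As far as these compounds go, it also remains open how 3-methoxybenzyl, or a longer chain ending in an amine or a carboxylic acid, would behave at this same place on the shared core.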